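Ester to ketone on the shared core: solubility outlook

The source may hold more compounds than are shown below. What is called first, only, known or untested is meant among the compounds shown, and "the series" means these compounds.

Compound 1 `CCOC(=O)c1cccc(Nc2ccnc(-c3ccncc3)n2)c1`: 46000 nM
Compound 2 `CCOC(=O)c1cccc(Nc2ccnc(-c3cccnc3)n2)c1`: 92000 nM

Among the measured compounds shown here, in a physicochemical assay for solubility, in phosphate buffer (on this read-out lower numbers stand for lower solubility and higher numbers for higher solubility), compound 2 gives 92000 nM and compound 1 gives 46000 nM; the single measured step, a 2.0-fold higher number from compound 1 to compound 2 (0.30 log units; within the scatter), leaves the two within the scatter of each other. Compound 3 `CC(=O)c1cccc(Nc2ccnc(-c3cccnc3)n2)c1` differs from compound 2 by methyl in place of ethoxy on a carbonyl carbon. For the measured compounds named here, no measured pair touches the carbonyl carbon, so no measured step bears directly on this change. The step is expected to stay within the scatter, a 1.2-fold higher number from compound 2 to compound 3 (0.08 log units; within the scatter). For compound 3 the estimated solubility is 110000 nM, with a range of 40000 nM to 300000 nM.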

Compound 3, solubility: 97000 nM
Compound 3: the middle estimate sits 1.1-fold (0.05 log units) above what was measured, and the stated range covers the measured number.
By their numbers in this assay, from the lowest: compounds 1, 2 and 3 (each within the scatter of the next, the first and the last beyond it).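

Among the compounds shown here, replacing ethoxy with methyl on the carbonyl carbon gives a 1.1-fold higher number from compound 2 to compound 3 (0.02 log units; within the scatter) in this assay and provides the first measured step at this position. Within this pair, the ethoxycarbonyl group can give way to acetyl with the two compounds remaining within the scatter of each other. No supporting measurement explains this result.

Still open, going by these compounds, is whether an amine or a carboxylic acid on the carbonyl carbon, or a longer chain there, would stay within the scatter. The compounds shown also leave open whether acetyl behaves alike with pyridin-4-yl in place of pyridin-3-yl.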